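The source may hold more compounds than are shown below. What is called first, only, known or untested is meant among the compounds shown, and "the series" means these compounds.

Working notes on the series.

Three compounds have been run in a functional assay on MCF7 cells (Homo sapiens) for cytotoxicity, read by MTT assay, with a stated time of 72 h, tested at 10 uM; on this read-out higher numbers stand for more inhibition of growth at the one concentration tested and lower numbers for less inhibition of growth. Compound 1 `N/C(=N\NC(=S)N1CCCCCC1)c1ccccn1` gives 62.2%. Compound 2 `N/C(=N\NC(=S)N1CCOCC1)c1ccccn1` gives 66.7%; this number and that of compound 1 lie within the scatter of each other, so no order is claimed between them. The difference between the two cores of compound 1 and compound 2 is not broken down here. Compound 3 `N/C(=N\NC(=S)N1CCOCC1)c1ccc(F)cn1` gives 39.5%. It is made from compound 2 by one change, (fluoro in place of hydrogen on an aromatic carbon), and the step is a number 27.2 percentage points lower from compound 2 to compound 3 (beyond the scatter).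

Compound 4 `N/C(=N\NC(=S)N1CCCCCC1)c1ccc(F)cn1` has not yet been measured in this assay. It stands to compound 1 as compound 3 stands to compound 2: the change is fluoro in place of hydrogen on an aromatic carbon, the same kind of change, and the place lines of both changes read the same word for word.

For the measured compounds named here, the expectation for compound 4 rests on the single measured example of this change. Going by the values given here, since the step from compound 2 to compound 3 is the only guide, a step of about the same size, a number 26.2 percentage points lower from compound 1 to compound 4 (beyond the scatter), is expected from compound 1 to compound 4, starting from the value of compound 1, 62.2%. On that basis compound 4 is estimated at 36% in this assay, with the range 22% to 52% allowing for the scatter and for the change having been seen only once.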

Compound 4, percent growth inhibition at one concentration: 26.8%
Compound 4: middle estimate off by 9.2 percentage points, on the high side; the measured number falls inside the stated range.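

The fluoro change now has a second reading in this assay, and the new step is a number 35.4 percentage points lower from compound 1 to compound 4 (beyond the scatter). Set beside the earlier step, it runs the same way and the two sizes do not differ beyond the scatter, so within this series the change carries from the core of compound 2 to the core of compound 1 with its direction and approximate size kept: the same change on two cores in this assay, a number 27.2 percentage points lower (beyond the scatter) from compound 2 to compound 3 and a number 35.4 percentage points lower (beyond the scatter) from compound 1 to compound 4, 8.2 percentage points apart, within the scatter of two such steps

This rests on two pairs only, both with the fluoro in the same place and both read at a single concentration, so it gives no rule for other cores and says nothing of why growth inhibition falls.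

The compounds shown leave open whether the same step would follow a chloro, a methyl or a methoxy group at that place, or a fluoro elsewhere on the six-membered aromatic ring. Also open, on these data alone, is whether the step holds when a dimethylamino group stands in place of the saturated rings of compound 1 and compound 2.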